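Swapping the bis(2-hydroxyethyl) end for a halogenated aryl group

The source may report more compounds than this note shows. Statements on the series, on what has been measured and on what is new or still open speak of the compounds shown alone.

In a functional assay on MCF7 cells (Homo sapiens) for inhibition, read by MTT assay, with a stated time of 4 days (on this read-out lower numbers stand for stronger inhibition and higher numbers for weaker inhibition), compound 1 (`COc1cc(NC(C)CCCNC(=O)NNC(=O)NCCO)c2ncccc2c1`) gives 13000 nM and compound 2 (`COc1cc(NC(C)CCCNC(=O)NNC(=O)N(CCO)CCO)c2ncccc2c1`) gives 29000 nM. Compound 2 therefore stands highest of the two measured compounds, with the weaker inhibition of the pair.

Compound 3 (`COc1cc(NC(C)CCCNC(=O)Nc2ccc(Cl)c(C(F)(F)F)c2)c2ncccc2c1`) keeps the shared core but changes the far end of the chain: 4-chloro-3-(trifluoromethyl)phenyl in place of (bis(2-hydroxyethyl)carbamoyl)amino on an amide-type nitrogen. Put simply, 4-chloro-3-(trifluoromethyl)phenyl takes the place of (bis(2-hydroxyethyl)carbamoyl)amino on an amide-type nitrogen. No 2-hydroxyethyl group remains, and neither measured compound carries an aromatic ring at this place.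

Within the data shown here, only one measured step bears on this change: a 2.2-fold higher number from compound 1 to compound 2 (0.35 log units; beyond the scatter). That modest step came with one added 2-hydroxyethyl, within the part that now leaves entirely. It hints at direction, but it says little about size, since the new exchange is far wider. A lower number is therefore expected in this assay, with an estimated move of a 9.7-fold lower number from compound 2 to compound 3 (0.99 log units; beyond the scatter). Compound 3 is estimated at 3000 nM, with an expected range from 400 nM to 15000 nM.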

Compound 3, half-maximal inhibitory concentration: 4000 nM
Compound 3: the middle estimate sits 1.3-fold (0.12 log units) below what was measured; measured number inside the range.
By their numbers in this assay, from the lowest: compound 3; then compound 1; then compound 2.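

In this assay, the exchange of (bis(2-hydroxyethyl)carbamoyl)amino for 4-chloro-3-(trifluoromethyl)phenyl on an amide-type nitrogen gives a 7.3-fold lower number from compound 2 to compound 3 (0.86 log units; beyond the scatter), which shows that this position can carry an aromatic ring with a lower number than either of the earlier ends. Set against the ((2-hydroxyethyl)carbamoyl)amino end of compound 1, the same group still gives a 3.3-fold lower number from compound 1 to compound 3 (0.51 log units; beyond the scatter), so the lower number of compound 3 does not depend on comparison with the weaker bis(2-hydroxyethyl) end alone. No measurement shown here accounts for why the number falls with this exchange.

The exchange removes the whole carbamoylamino end and brings in the ring, the chlorine and the trifluoromethyl together, so the compounds shown leave open which of these changes carries the step. A plain phenyl, a 4-chlorophenyl and a 3-(trifluoromethyl)phenyl at this place would separate those parts, while a phenyl bearing a carboxylic acid or an amine would show whether this position keeps the lower number with such groups on the ring.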